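The source may hold more compounds than are shown below. What is called first, only, known or untested is meant among the compounds shown, and "the series" means these compounds.

Series notes. Three compounds share one core and carry a sulfonyl-linked morpholine on it: compound 1 `N=c1oc2ccccc2cc1C(=O)N/N=C1\C(=O)Nc2ccc(S(=O)(=O)N3CCOCC3)cc21`, compound 2 `O=C1Nc2ccc(S(=O)(=O)N3CCOCC3)cc2/C1=N/c1ccc(O)cc1` and compound 3 `O=C1Nc2ccc(S(=O)(=O)N3CCOCC3)cc2/C1=N/c1ccc(/N=C2\C(=O)Nc3ccc(S(=O)(=O)N4CCOCC4)cc32)cc1`. In an ADME assay on WI-38 cells (Homo sapiens) for cytotoxicity, read by sulforhodamine B assay, with a stated time of 24 h (on this read-out higher numbers stand for weaker inhibition and lower numbers for stronger inhibition), compound 1 gives 132000 nM, compound 2 gives 259000 nM and compound 3 gives 203000 nM. The three numbers lie within the usual scatter of one another, so compound 2 cannot be set apart from compound 1 or compound 3 on this assay alone.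

Compound 4 `Cc1ccc(/N=C2\C(=O)Nc3ccc(S(=O)(=O)N4CCOCC4)cc32)cc1` is not yet measured. It differs from compound 2 in one place: methyl in place of hydroxy on an aromatic carbon. For the measured compounds named here, no pair of measured compounds isolates such a change, so there is no precedent here for its size or direction.

Given that the measured set spans only the scatter, the step from compound 2 to compound 4 is expected to be a 1.0-fold lower number from compound 2 to compound 4 (0.02 log units; within the scatter), that is, none beyond the scatter in either direction. Compound 4 is therefore estimated at 250000 nM in this assay, with a range from 120000 nM to 500000 nM.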

Compound 4, half-maximal inhibitory concentration: 309000 nM
Compound 4: middle estimate off by 1.2-fold (0.09 log units), on the low side; measured number inside the range.
By their numbers in this assay, from the lowest: compounds 1, 3, 2 and 4 (each within the scatter of the next, the first and the last beyond it).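

In this assay, for the compounds shown here, a 1.2-fold higher number from compound 2 to compound 4 (0.08 log units; within the scatter) is the first reading of a change in one place, and it is a step within the scatter. At this position, on an aromatic carbon para to a large group, going from 4-hydroxyphenyl to 4-methylphenyl removes the hydrogen-bond donor and acceptor of the hydroxy group without moving the number beyond the scatter, so this assay does not separate the two groups. Nothing available bears on why the number holds.

A single step says nothing about whether an amine, a carboxylic acid or a longer alkyl chain at the same position would also stay within the scatter. It also leaves open whether methyl in place of hydroxy would read the same way on the other compounds of the series.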